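A few compounds are considered here, and "the series" means these few. Any claim that something is new, unique, unknown or untested is made for them only; others in the source may bear on it.

Working notes on the series. Three measured members share one core: compound 1 `O=C1C=C(Nc2ccc(I)cc2)C(=O)c2c1nc1n2[C@H]2OC[C@@H](O)[C@H]2OC1`, compound 2 `O=C1C(Nc2cccc(Cl)c2)=CC(=O)c2c1nc1n2[C@H]2OC[C@@H](O)[C@H]2OC1` and compound 3 `CCOc1ccccc1NC1=CC(=O)c2nc3n(c2C1=O)[C@H]1OC[C@@H](O)[C@H]1OC3`. In a functional assay on MGC-803 cells (Homo sapiens) for inhibition, read by sulforhodamine B assay (on this read-out lower numbers stand for stronger inhibition and higher numbers for weaker inhibition), compound 1 gives 1400 nM, compound 2 gives 1530 nM and compound 3 gives 2450 nM. Compound 2 stands second highest of the three numbers, nearest to compound 1 and furthest from compound 3, both gaps within the scatter. Among the measured compounds shown here, the only single-point step measured is a 1.8-fold higher number from compound 1 to compound 3 (0.24 log units; within the scatter), a swap of one group on the amine nitrogen for another. Compound 4 `CCCN(CCC)C1=CC(=O)c2c(nc3n2[C@H]2OC[C@@H](O)[C@H]2OC3)C1=O` differs from compound 2 by dipropylamino in place of (3-chlorophenyl)amino on a double-bonded ring carbon. For the measured compounds named here, no measured step removes the aromatic ring and the hydrogen-bond donor together, so that step bears only loosely; a change no larger than the scatter, leaning upward, is expected. Compound 4 is estimated at 2600 nM, range 900 nM to 8000 nM. The expected step is a 1.7-fold higher number from compound 2 to compound 4 (0.23 log units; within the scatter).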

Compound 4, half-maximal inhibitory concentration: > 16000 nM
Compound 4 gave a limit, no number; the forecaster's own chance of this, stated with the estimate: 8%; middle value at least 6.1-fold (0.78 log units) away from the limit.
By their numbers in this assay, from the lowest: compounds 1, 2 and 3 (each within the scatter of the next). At a limit, above all of these: compound 4.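

In this assay compound 4 gives a limit and not a number: the limit of > 16000 nM in this assay, at which 1 of the 4 values shown sits.

Among the compounds shown here, the step of an at least 10-fold higher number from compound 2 to compound 4 (1.01 log units; beyond the scatter) is the first beyond the scatter, whereas the only earlier step, a 1.8-fold higher number from compound 1 to compound 3 (0.24 log units; within the scatter), keeps an aromatic ring and the amine hydrogen. On this double-bonded ring carbon, then, dipropylamino is not interchangeable with (3-chlorophenyl)amino.

Going by these compounds, the aromatic ring and the hydrogen-bond donor leave together, so which of them matters stays open. A propylamino group would keep the donor without the ring, and a methyl(phenyl)amino group the ring without the donor.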